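Working notes: chain-end swap from compound 3 to compound 4

The source may hold more compounds than are shown below. What is called first, only, known or untested is meant among the compounds shown, and "the series" means these compounds.

Measured compounds:
compound 1 `O=c1[nH]/c(=N\OCCOc2ccccc2)ccn1[C@@H]1O[C@H](COP(=O)(O)OP(=O)(O)OP(=O)(O)O)[C@@H](O)[C@H]1O` — 1780 nM
compound 2 `COc1ccc(CCCO/N=c2/ccn([C@@H]3O[C@H](COP(=O)(O)OP(=O)(O)OP(=O)(O)O)[C@@H](O)[C@H]3O)c(=O)[nH]2)cc1` — 277 nM
compound 3 `O=c1[nH]/c(=N\OCCCc2cccnc2)ccn1[C@@H]1O[C@H](COP(=O)(O)OP(=O)(O)OP(=O)(O)O)[C@@H](O)[C@H]1O` — 2950 nM

All three were read in a functional assay on 1321-N1 cells for agonist activity at P2Y purinoceptor 6 (Homo sapiens), read by scintillation counting and inositol phosphate accumulation; on this read-out lower numbers stand for an effect already at smaller amounts and higher numbers for an effect only at larger amounts of compound. Compound 3 gives the highest number of the three. Against compound 1 the gap is small: a 1.7-fold higher number from compound 1 to compound 3 (0.22 log units; within the scatter). Against compound 2 the gap is real: an 11-fold higher number from compound 2 to compound 3 (1.03 log units; beyond the scatter). The remaining pair, compound 1 and compound 2, shows a 6.4-fold lower number from compound 1 to compound 2 (0.81 log units; beyond the scatter), so within this set the 4-methoxyphenyl end stands apart from both the phenoxy and the pyridin-3-yl ends.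

Compound 4 `C#CCCCO/N=c1/ccn([C@@H]2O[C@H](COP(=O)(O)OP(=O)(O)OP(=O)(O)O)[C@@H](O)[C@H]2O)c(=O)[nH]1` differs from compound 3 in one place: ethynyl in place of pyridin-3-yl on a saturated chain carbon, three bonds along the chain from an oxygen. Among the measured compounds shown here, no measured step removes the ring at the chain end altogether; every measured step swaps one ring for another. For the measured compounds named here, the steps that bear on the change are therefore only indirect: the ring swap from compound 2 to compound 3 moved this assay a lot, while the swap from compound 1 to compound 3 did not. Given that compound 3 already sits at the high end and that the ring which is lost is the one whose exchange mattered most, compound 4 is expected to give a number similar to or higher than compound 3, with the step of a 1.5-fold higher number from compound 3 to compound 4 (0.18 log units; within the scatter) expected. The estimate for compound 4 in this assay is 4500 nM, with a range from 1200 nM to 17000 nM.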

Compound 4, half-maximal effective concentration: 3000 nM
For compound 4 the middle estimate is 1.5-fold (0.18 log units) above the measured one; the range from low to high includes it.
By their numbers in this assay, from the lowest: compound 2; then compounds 1, 3 and 4 (each within the scatter of the next).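

In this assay, a 1.0-fold higher number from compound 3 to compound 4 (0.01 log units; within the scatter) shows that ethynyl in place of pyridin-3-yl, on a saturated chain carbon three bonds along the chain from an oxygen, gives no readable change, so among these compounds the aromatic ring at the chain end is not needed to hold this level. With a 1.7-fold higher number from compound 1 to compound 4 (0.23 log units; within the scatter) also printed as within the scatter and an 11-fold higher number from compound 2 to compound 4 (1.03 log units; beyond the scatter) printed as beyond it, the ringless end joins the phenoxy and pyridin-3-yl ends, and only the 4-methoxyphenyl end of compound 2 stands apart. Nothing available beyond these numbers accounts for the flat step or for the separate place of compound 2.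

Still open, from the compounds shown here alone, is what in the 4-methoxyphenyl end goes with the lower number of compound 2, a question that an unsubstituted 3-phenylpropyl chain or a 4-aminophenyl or 4-carboxyphenyl end on the same chain could help to settle. Also open, going by these compounds, is whether the ethynyl end depends on chain length, which a longer chain carrying the same ethynyl group or a saturated pentyl chain would test.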